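Working notes: substituents on the aromatic ring nitrogen

The compounds below may be only part of what the source reports. "The series", "measured", "known", "first", "only" and "open" are said of these compounds alone.

Measured so far:
compound 1, `Cn1nc(Cc2nnc(SCCCCCCCC(=O)Nc3ccc(Cl)cc3Cl)n2CCC=O)c2ccccc2c1=O`: 960 nM
compound 2, `Cn1nc(Cc2nnc(SCCCCCCCC(=O)Nc3ccc(Cl)cc3Cl)[nH]2)c2ccccc2c1=O`: 450 nM

Both numbers come from an assay on NK92 cells for inhibition of interleukin-2 (Homo sapiens), read by AlphaScreen, with stated times of 30 min and 1 h; on this read-out lower numbers stand for stronger inhibition and higher numbers for weaker inhibition. For the measured compounds named here, compound 2 stands lowest of the two, and its only neighbour is compound 1; the pair is joined by a 2.1-fold lower number from compound 1 to compound 2 (0.33 log units; beyond the scatter), a modest step beyond the scatter.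

Compound 3, `Cn1nc(Cc2nnc(SCCCCCCCC(=O)Nc3ccc(Cl)cc3Cl)n2CCCO[Si](C)(C)C(C)(C)C)c2ccccc2c1=O`, has not been measured. Relative to compound 2 it carries a group of 11 heavy atoms (9 carbon, 1 oxygen, 1 silicon; no ring) in place of a hydrogen atom, on an aromatic nitrogen. Going by the values given here, the one measured step that touches this ring nitrogen is a 2.1-fold lower number from compound 1 to compound 2 (0.33 log units; beyond the scatter), in which a hydrogen replacing a substituent there lowered the number. Compound 3 runs that step the other way with a much larger group, so the number is expected to move back up in this assay, by at least the size seen between compound 1 and compound 2, with wide uncertainty since no substituent of this kind has been tried.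

Compound 3 is therefore estimated at 1200 nM (range 400 nM to 4000 nM) in this assay. The expected step is a 2.7-fold higher number from compound 2 to compound 3 (0.43 log units; beyond the scatter).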

Compound 3, half-maximal inhibitory concentration: > 30000 nM
Compound 3: only a limit was reported; the forecaster's own chance of this, stated with the estimate: 10%; middle value at least 25-fold (1.39 log units) away from the limit.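

In this assay compound 3 is reported only as a limit: the limit of > 30000 nM in this assay, at which 1 of the 3 values shown sits.

The earlier pair showed only a modest change at this aromatic nitrogen, whereas a group of 11 heavy atoms (9 carbon, 1 oxygen, 1 silicon; no ring) in place of a hydrogen atom gives an at least 66-fold higher number from compound 2 to compound 3 (1.82 log units; beyond the scatter), so the position is far from indifferent to what it carries. Changing only the end of the substituent, on a saturated chain carbon, two bonds along the chain from an aromatic nitrogen, gives an at least 31-fold higher number from compound 1 to compound 3 (1.49 log units; beyond the scatter), so substitution on the nitrogen as such does not account for the full size of the change.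

The compounds shown do not separate the size of the entering group from the presence of silicon. A 3-hydroxypropyl or a plain methyl group on this nitrogen would bear on that question.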